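Replacing a tert-Butylphenyl Group with a Methoxyphenoxy Ether

A few compounds are considered here, and "the series" means these few. Any claim that something is new, unique, unknown or untested is made for them only; others in the source may bear on it.

Compound 1 `Fc1ccc(Cc2ccc3c(NCCCNCc4ccco4)ccnc3c2)cc1`: 23 10^-6 cm/s
Compound 2 `CC(C)(C)c1ccc(-c2ccc3c(NCCCNCc4ccco4)ccnc3c2)cc1`: 237 10^-6 cm/s

Two measured compounds share one core and differ only in the group attached to an aromatic carbon. In an ADME assay for permeability, using PAMPA, with a stated time of 30 min, at pH 7.4 (on this read-out lower numbers stand for lower permeability and higher numbers for higher permeability), compound 1 gives 23 10^-6 cm/s, and compound 2 gives 237 10^-6 cm/s. The step of a 10-fold higher number from compound 1 to compound 2 (1.01 log units; beyond the scatter) shows that a change at this position can move the read-out strongly. Compound 2 stands highest of the two numbers, with compound 1 the only other and far lower.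

Compound 3 `COc1ccccc1Oc1ccc2c(NCCCNCc3ccco3)ccnc2c1` has not yet been measured. It differs from compound 2 by 2-methoxyphenoxy in place of 4-(tert-butyl)phenyl on an aromatic carbon. No measured step matches this exact exchange; the single step shown, a 10-fold higher number from compound 1 to compound 2 (1.01 log units; beyond the scatter), involves different groups and tells only that this position matters. Compound 3 is expected to fall below compound 2, by about a 4.0-fold lower number from compound 2 to compound 3 (0.60 log units; beyond the scatter), in this assay. The estimate for compound 3 is 60 10^-6 cm/s, with a range from 20 10^-6 cm/s to 180 10^-6 cm/s.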

Compound 3, apparent permeability: 317 10^-6 cm/s
Estimate against measurement, compound 3: 5.3-fold (0.72 log units) below; measured number above the stated range.
By their numbers in this assay, from the lowest: compound 1; then compounds 2 and 3 (each within the scatter of the next).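

In this assay, the exchange of 4-(tert-butyl)phenyl for 2-methoxyphenoxy gives a 1.3-fold higher number from compound 2 to compound 3 (0.13 log units; within the scatter), so an all-carbon group and a group holding 2 oxygen atoms read alike at this aromatic carbon. The exchange of 4-fluorobenzyl for 2-methoxyphenoxy gives a 14-fold higher number from compound 1 to compound 3 (1.14 log units; beyond the scatter), which shows that the large gap first seen at this position is not tied to 4-(tert-butyl)phenyl alone. No measurement shown offers an explanation for either result.

The compounds shown leave open whether a plain phenoxy group, without the methoxy, would read like 2-methoxyphenoxy. They also leave open where an amine or a carboxylic acid at this carbon would fall, whether close to compound 1 or close to compound 3.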